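The source may report more compounds than this note shows. Statements on the series, on what has been measured and on what is new or still open speak of the compounds shown alone.

Measured in a functional assay on MKN-45 cells (Homo sapiens) for antiproliferative activity, read by CellTiter-Glo, with a stated time of 3 days; a higher number here means a weaker inhibitor, a lower number a stronger inhibitor:
- compound 1 `CC(Oc1c(N)ncc2c(-c3cnn(C4CCNCC4)c3)coc12)c1cccc(F)c1Cl`: 5100 nM
- compound 2 `CC(Oc1c(N)ncc2c(-c3cnn(C4CCNCC4)c3)coc12)c1c(Cl)c(F)cc(F)c1Cl`: 480 nM

Compound 2, at 480 nM, has the lower of the two numbers. Compound 3 `CC(Oc1c(N)ncc2c(-c3cnn(C4CCNCC4)c3)coc12)c1c(Br)ccc(F)c1Cl` is the next to read: a group of 9 heavy atoms (6 carbon, 1 fluorine, 1 chlorine, 1 bromine; one six-membered aromatic ring of carbon only) in place of a group of 10 heavy atoms (6 carbon, 2 fluorine, 2 chlorine; one six-membered aromatic ring of carbon only), on a saturated chain carbon bound to an oxygen on an aromatic ring and a saturated chain carbon. The change falls on a saturated chain carbon bound to an oxygen on an aromatic ring and a saturated chain carbon. Among the measured compounds shown here, the only measured step at this place is large: an 11-fold lower number from compound 1 to compound 2 (1.03 log units; beyond the scatter). It shows that the number can respond to the group here, but it involves no bromine, so no direction can be drawn from it. No step beyond the scatter is therefore expected in this assay. The expected change is a 1.1-fold higher number from compound 2 to compound 3 (0.06 log units; within the scatter). For compound 3 the estimate is 550 nM, with an expected range of 220 nM to 1400 nM.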

Compound 3, half-maximal inhibitory concentration: 510 nM
Compound 3: middle estimate off by 1.1-fold (0.03 log units), on the high side; measured number inside the range.
By their numbers in this assay, from the lowest: compounds 2 and 3 (each within the scatter of the next); then compound 1.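

In this assay, among the compounds shown here, bromo in place of hydrogen on an aromatic carbon gives a 10-fold lower number from compound 1 to compound 3 (1.00 log units; beyond the scatter) as the first step at this place that involves bromine. The bromine-bearing group and the group of compound 2 give a 1.1-fold higher number from compound 2 to compound 3 (0.03 log units; within the scatter) and so are not separated by these numbers.

From the compounds shown here alone, whether a methyl, a nitrile or an amine in place of the bromo would keep the number at this level stays open. Nothing available bears on the reason for either step.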